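Cytotoxicity on MT2 cells: a change at the amide side chain

The source may report more compounds than this note shows. Statements on the series, on what has been measured and on what is new or still open speak of the compounds shown alone.

Measured in an ADME assay on MT2 cells (Homo sapiens) for cytotoxicity; on this read-out lower numbers stand for higher toxicity in this test and higher numbers for lower toxicity in this test:
Compound 1, `Cc1nc2cc(C(=O)NCc3ccc(F)cc3O)nn2c(-c2cc(F)c3c(c2C)CCCO3)c1[C@H](OC(C)(C)C)C(=O)O`: > 40000 nM, a limit of the assay.
Compound 2, `CCCNC(=O)c1cc2nc(C)c([C@H](OC(C)(C)C)C(=O)O)c(-c3cc(F)c4c(c3C)CCCO4)n2n1`: > 40000 nM, a limit of the assay.
Compound 3, `Cc1nc2cc(C(=O)NCCC3CCCCC3)nn2c(-c2cc(F)c3c(c2C)CCCO3)c1[C@H](OC(C)(C)C)C(=O)O`: > 40000 nM, a limit of the assay.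

Compound 1 stands only at a limit, not at a number, like the two other values shown. The step that the two limits leave unreadable from compound 1 to compound 2 and the step that the two limits leave unreadable from compound 1 to compound 3 change the same position as the step to compound 4, and the step that the two limits leave unreadable from compound 2 to compound 3 also sits there, yet none of them can be read because of the limit of > 40000 nM in this assay, at which 3 of the 3 values shown sit. Compound 4, `Cc1nc2cc(C(=O)NCCC3CCOCC3)nn2c(-c2cc(F)c3c(c2C)CCCO3)c1[C@H](OC(C)(C)C)C(=O)O`, carries (oxan-4-yl)methyl in place of 4-fluoro-2-hydroxyphenyl on a saturated chain carbon bound to an amide-type nitrogen. Among the measured compounds shown here, no measured step points in either direction beyond the scatter, so the step of a number no higher from compound 1 to compound 4 (the limit leaves the size open) is expected to be none beyond the scatter. Compound 4 is expected at 40000 nM, between 20000 nM and 80000 nM.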

Compound 4, half-maximal cytotoxic concentration: > 40000 nM
Compound 4: only a limit was reported (the forecaster's own chance of this, stated with the estimate: 85%); the middle value lies on the limit itself.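

The steps from compound 1, compound 2 and compound 3 to compound 4 cannot be read, because compound 4 also gives only a limit: the limit of > 40000 nM in this assay, at which 4 of the 4 values shown sit.

From the compounds shown here alone, whether these amide side chains differ at all in this assay stays open.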